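The source may report more compounds than this note shows. Statements on the series, on what has been measured and on what is new or still open speak of the compounds shown alone.

Measured so far, in an assay on HEK293 cells for antagonist activity at Voltage-dependent L-type calcium channel subunit alpha-1C (Oryctolagus cuniculus), read by FLIPR; a lower number here means a stronger inhibitor, a higher number a weaker inhibitor:

compound 1 `CC1=C(C(=O)OC(C)C)C(c2cccc([N+](=O)[O-])c2)NC(=O)N1` – 58100 nM
compound 2 `COC(=O)C1=C(C(C)C)NC(=O)NC1c1cccc([N+](=O)[O-])c1` – > 100000 nM
compound 3 `COC(=O)C1=C(C)NC(=S)NC1c1cccc([N+](=O)[O-])c1` – 55000 nM

Compound 2 gives no number in this assay; its value is a limit of the assay. Compound 3 and compound 1 give numbers that lie within the usual scatter of each other, so no order between them can be read from these two values.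

Compound 4 `CC1=C(C(=O)OC(C)C)C(c2cccc([N+](=O)[O-])c2)NC(=S)N1` has not yet been measured. It differs from compound 3 in one place: isopropyl in place of methyl on an oxygen next to a carbonyl group. Among the measured compounds shown here, no pair of measured compounds differing only in this way is available, so the size of this step is not known from measurement. The expected step from compound 3 to compound 4 is a 1.2-fold lower number from compound 3 to compound 4 (0.09 log units; within the scatter), which is small and not beyond the scatter. For compound 4 the estimate in this assay is 45000 nM, within a range from 15000 nM to 100000 nM.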

Compound 4, half-maximal inhibitory concentration: 10700 nM
Estimate against measurement, compound 4: 4.2-fold (0.62 log units) above; measured number below the stated range.
By their numbers in this assay, from the lowest: compound 4; then compounds 3 and 1 (each within the scatter of the next). At a limit, above all of these: compound 2.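

In this assay, putting isopropyl in place of methyl on an oxygen next to a carbonyl group gives a 5.1-fold lower number from compound 3 to compound 4 (0.71 log units; beyond the scatter). Among the compounds shown here, this is the first measured sign that the assay registers a change at this position, though the finding rests on this single pair. Nothing shown here says why the number falls. As far as these compounds go, whether ethyl, a longer chain such as butyl, or a chain ending in an amine would give a lower number at this position remains open. So does whether the same change would give a similar step on the core of compound 1.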